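A few compounds are considered here, and "the series" means these few. Any claim that something is new, unique, unknown or untested is made for them only; others in the source may bear on it.

Measured so far in a physicochemical assay for acid dissociation:
compound 1, `COc1ccc(F)cc1CNCCCNc1ccnc2cc(Cc3ccc(C#N)cc3)ccc12`: 9.47
compound 2, `CC(C)(C)c1ccc(-c2ccc3c(NCCCNCc4ccco4)ccnc3c2)cc1`: 9.47
compound 3, `COc1cccc(CNCCCNc2ccnc3cc(Oc4cccc(N(C)C)c4)ccc23)c1O`: 9.28

Compound 1 stands level with compound 2 at the digits printed, the two together the highest of the three numbers, while compound 3 gives a number that lies within the scatter of both, so no order can be read among them. Compound 4, `COc1ccc(F)cc1CNCCCNc1ccnc2cc(Cc3cc(C)cc(C)c3)ccc12`, is to be measured in this assay. From compound 1 it differs in one place: 3,5-dimethylphenyl in place of 4-cyanophenyl on a saturated chain carbon bound to an aromatic carbon. Within the data shown here, no pair of measured compounds differs in only one place, so nothing isolates the effect of such a swap; what is known is that compounds 1, 2 and 3, which differ from each other in several places, all fall within the scatter of one another. No step beyond the scatter is therefore expected from compound 1 to compound 4, and the step is estimated at a number 0.03 log units higher from compound 1 to compound 4 (within the scatter). Compound 4 is expected to give about 9.5, in the range 9.2 to 9.8.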

Compound 4, acid dissociation constant: 9.47
The estimate for compound 4 lay 0.03 log units above the measured number, and the stated range covers the measured number.
By their numbers in this assay, from the lowest: compounds 3, 1, 2 and 4 (each within the scatter of the next).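

In this assay, among these compounds, 3,5-dimethylphenyl in place of 4-cyanophenyl on a saturated chain carbon bound to an aromatic carbon gives no change at the digits printed from compound 1 to compound 4 (within the scatter), the first step that isolates a single place. At this position, the read-out therefore tolerates loss of the nitrile and its hydrogen-bond acceptor, with the count of heavy atoms held equal. Nothing available explains this result.

The compounds shown leave open whether a carboxylic acid or an amine on this benzyl ring would shift the number. They also leave open whether the same swap gives the same step with the furan-bearing side chain of compound 2.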